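The source may hold more compounds than are shown below. What is called first, only, known or untested is meant among the compounds shown, and "the series" means these compounds.

Compound 2 `Nc1ccccc1/C=C/c1ccc(O)cc1` is one of three measured compounds. In a functional assay on HT-29 cells (Homo sapiens) for inhibition, read by MTT assay, with a stated time of 2 days (a higher number here means a weaker inhibitor, a lower number a stronger inhibitor), compound 2 reaches only the limit of the assay, > 100 ug/mL, which is a bound rather than a number. Compound 1 `Oc1ccc(/C=C/c2ccccc2O)cc1` carries a hydroxy where compound 2 carries an amino, and in this assay compound 1 gives 22 ug/mL. Compound 3 `Nc1cccc(/C=C/c2ccc(O)cc2)c1` is another amino-bearing compound, and in this assay compound 3 gives 51 ug/mL. Within the data shown here, the only single-change step recorded is an at least 4.5-fold higher number from compound 1 to compound 2 (0.65 log units; beyond the scatter), and its size is known only as a bound because compound 2 sits at the limit of > 100 ug/mL in this assay, at which 1 of the 3 values shown sits. Compound 4 `COc1ccccc1/C=C/c1ccc(O)cc1` is not yet measured. The change from compound 2 to compound 4 is methoxy in place of amino on an aromatic carbon. Among the measured compounds shown here, no measured step swaps amino for methoxy; the step from compound 1 to compound 2 shows that the amino went with a weaker result, so taking it away points toward a lower number, though methoxy is not hydroxy and the size is uncertain. Compound 4 is therefore expected at about 60 ug/mL, with a range from 20 ug/mL to 150 ug/mL. The expected step from compound 2 to compound 4 is an at least 1.6-fold lower number from compound 2 to compound 4 (0.22 log units; that floor lies within the scatter).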

Compound 4, half-maximal inhibitory concentration: 24 ug/mL
The estimate for compound 4 lay 2.5-fold (0.40 log units) above the measured number; low and high end bracket the measured number.
By their numbers in this assay, from the lowest: compounds 1 and 4 (each within the scatter of the next); then compound 3. At a limit, above all of these: compound 2.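

In this assay, on this aromatic carbon, ortho to a group of 9 heavy atoms, the swap of amino for methoxy gives an at least 4.1-fold lower number from compound 2 to compound 4 (0.61 log units; beyond the scatter). That size is a floor and not an exact figure: the limit of > 100 ug/mL in this assay, at which 1 of the 4 values shown sits.

Putting a methyl on the oxygen of the hydroxy gives a 1.1-fold higher number from compound 1 to compound 4 (0.04 log units; within the scatter), so among compounds 1, 2 and 4 the two oxygen-linked groups cannot be told apart, while the amino stands apart from both.

The compounds shown cannot say whether an oxygen on this carbon is what matters, or whether removing the amino alone would give the same result. A longer ethoxy, a chlorine or a plain hydrogen at this place would help to separate these readings.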